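From compound 3 to compound 4: a chain change

The source may report more compounds than this note shows. Statements on the series, on what has been measured and on what is new or still open speak of the compounds shown alone.

Values in an in vitro ADME assay on microsomes from liver (Homo sapiens) for metabolic stability, tested at 5 uM (on this read-out lower numbers stand for a shorter-lived compound and higher numbers for a longer-lived compound), are as follows:
- Compound 1 `CC(C)CCn1nc(-c2ccccc2)c(O)c(C2=NS(=O)(=O)c3cc(NS(C)(=O)=O)ccc3N2)c1=O` gives 0.633 h
- Compound 2 `CC(C)CCc1nn(CCC(C)C)c(=O)c(C2=NS(=O)(=O)c3cc(NS(C)(=O)=O)ccc3N2)c1O` gives 0.167 h
- Compound 3 `CC(C)(C)CCn1nc(-c2cccs2)c(O)c(C2=NS(=O)(=O)c3cc(NS(C)(=O)=O)ccc3N2)c1=O` gives > 1 h (a limit, not a number)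

Compound 3 has no number in this assay and stands only at a limit (the limit of > 1 h in this assay, at which 1 of the 3 values shown sits). Compound 4 `CS(=O)(=O)Nc1ccc2c(c1)S(=O)(=O)N=C(c1c(O)c(-c3cccs3)nn(CC3CCC3)c1=O)N2` differs from compound 3 at one place (cyclobutyl in place of neopentyl on a saturated chain carbon bound to an aromatic nitrogen): cyclobutyl in place of neopentyl on a saturated chain carbon bound to an aromatic nitrogen, which also reads as 3,3-dimethylbutyl to cyclobutylmethyl.

For the measured compounds named here, the one measured step is a 3.8-fold lower number from compound 1 to compound 2 (0.58 log units; beyond the scatter) with isopentyl in place of phenyl on an aromatic carbon. That step lies at another place and gives only a rough scale. Going by the values given here, no measured step changes the chain on the aromatic nitrogen. Going by these compounds, a step beyond the scatter is therefore not expected, and the direction stays open. The estimated step is an at least 1.1-fold lower number from compound 3 to compound 4 (0.04 log units; that floor lies within the scatter) and it is reckoned against a limit. In this assay the expected value for compound 4 is 0.9 h with an estimated range from 0.4 h to 2 h as the working figure.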

Compound 4, half-life: > 1 h
Compound 4 gave a limit, no number; the forecaster's own chance of this, stated with the estimate: 45%; middle value at least 1.1-fold (0.04 log units) from the limit.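

In this assay, for the compounds shown here, compound 4 gives > 1 h as a limit and not a number, as compound 3 also does, so no step from compound 3 to compound 4 can be read: the limit of > 1 h in this assay, at which 2 of the 4 values shown sit. The compounds shown leave open whether cyclobutyl in place of neopentyl on a saturated chain carbon bound to an aromatic nitrogen changes the half-life at all, and in which direction.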